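Chloro for Hydrogen on a Phenyl Ring Across Two Cores

The source may hold more compounds than are shown below. What is called first, only, known or untested is meant among the compounds shown, and "the series" means these compounds.

Measured compounds, in a functional assay on MCF7 cells (Homo sapiens) for inhibition, read by sulforhodamine B assay, with a stated time of 48 h; on this read-out higher numbers stand for weaker inhibition of growth and lower numbers for stronger inhibition of growth:
compound 1 `N#Cc1c(-c2nnc(-c3nn(-c4ccccc4)c(-c4ccccc4)c3C#N)c3nn(-c4ccccc4)cc23)nn(-c2ccccc2)c1-c1ccccc1` gives 17800 nM
compound 2 `N#Cc1c(-c2nnc(-c3nn(-c4ccccc4)c(-c4ccccc4)c3C#N)c3nn(-c4ccc(Cl)cc4)cc23)nn(-c2ccccc2)c1-c1ccccc1` gives 9420 nM
compound 3 `N#Cc1c(-c2nnc(-c3ccccc3)c3nn(-c4ccccc4)cc23)nn(-c2ccccc2)c1-c1ccccc1` gives 9530 nM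

Compound 1 and compound 2 share one core and differ in a single place: chloro in place of hydrogen on an aromatic carbon. In this assay this change made a 1.9-fold lower number from compound 1 to compound 2 (0.28 log units; within the scatter). Compound 3 has a different core; the difference between the core of compound 1 and the core of compound 3 is not broken down here. The values of compound 2 and compound 3 in this assay lie within the usual scatter of each other, and compound 3 likewise sits within the scatter of compound 1.

Compound 4 `N#Cc1c(-c2nnc(-c3ccccc3)c3nn(-c4ccc(Cl)cc4)cc23)nn(-c2ccccc2)c1-c1ccccc1` has not yet been measured. For the measured compounds named here, it differs from compound 3 by chloro in place of hydrogen on an aromatic carbon, which is the same change as the one from compound 1 to compound 2, made at the same kind of place and described in the same words.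

In this assay the step is expected to be a 1.6-fold lower number from compound 3 to compound 4 (0.20 log units; within the scatter), set beside the earlier 1.9-fold lower number from compound 1 to compound 2 (0.28 log units; within the scatter). This expectation rests on that single earlier instance, which lay within the scatter, so the estimate allows for a step that is small or absent on the second core.

Compound 4 is therefore estimated at 6000 nM. Its expected range runs from 2500 nM to 15000 nM.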

Compound 4, concentration for 50% growth inhibition: 43800 nM
Beside the measured number, compound 4's estimate is 7.3-fold (0.86 log units) below it; measured number above the stated range.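

In this assay, the change from phenyl to 4-chlorophenyl gave a 4.6-fold higher number from compound 3 to compound 4 (0.66 log units; beyond the scatter), so on this core the chloro compound showed weaker inhibition of growth, beyond the scatter. The change therefore did not carry over from one core to the other, and the two instances part by more than their scatter allows: the same change on two cores in this assay, a 1.9-fold lower number (0.28 log units; within the scatter) from compound 1 to compound 2 and a 4.6-fold higher number (0.66 log units; beyond the scatter) from compound 3 to compound 4, 8.7-fold (0.94 log units) apart, beyond the scatter of two such steps. This shows that the step seen on one core could not be taken as a guide to the step on the other in this series, but with one pair on each core and the first step lying within the scatter, it does not show which feature of the cores sets them apart, nor whether chloro truly helps on the core of compound 1.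

The compounds shown leave open whether other groups in the same place on the phenyl ring, such as fluoro, methoxy or an amine, would also behave differently on the two cores. They also leave open whether a larger set of pairs on each core would confirm the split between these two steps, or whether it is confined to this one pair of cores.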